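This account rests on a few compounds, and the source may have more. Where it says the series, first, only, none or still open, it means among the compounds named here.

Measured in a functional assay on cells (Panel NCI-60 (60 carcinoma cell lines), Homo sapiens) for inhibition, read by sulforhodamine B assay, with a stated time of 48 h; on this read-out higher numbers stand for weaker inhibition of growth and lower numbers for stronger inhibition of growth:
compound 1 `N=C(N)c1ccc(-c2ccc(-c3cncc4ccccc34)s2)s1` — 3230 nM
compound 2 `N=C(N)c1ccc(-c2ccc(-c3ccc(F)cc3)o2)o1` — 3460 nM

Of the two numbers, compound 2 stands with the higher one, yet the gap to compound 1 is within the scatter, so the two cannot be set in order. The step to compound 3 `N=C(N)c1ccc(-c2ccc(-c3ccc(Cl)cc3)o2)o1` is chloro in place of fluoro on an aromatic carbon. Among the compounds with values here, no step between measured compounds is known to guide it, so only a small shift in this assay, in either direction or none beyond the scatter, is expected. Compound 3 is therefore estimated at 3000 nM, with a range from 1400 nM to 6500 nM, an expected step of a 1.2-fold lower number from compound 2 to compound 3 (0.06 log units; within the scatter).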

Compound 3, concentration for total growth inhibition: 3720 nM
For compound 3 the middle estimate is 1.2-fold (0.09 log units) below the measured one; the measured number falls inside the stated range.
By their numbers in this assay, from the lowest: compounds 1, 2 and 3 (each within the scatter of the next).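

In this assay, within the data shown here, the change from fluoro to chloro on an aromatic carbon para to a large group gives a 1.1-fold higher number from compound 2 to compound 3 (0.03 log units; within the scatter) and is the first single-place step that can be read in this set. At this position, the two groups cannot be told apart on this read-out. Nothing measured here offers an explanation for this result. Going by these compounds, it remains open whether an amine, a methoxy group or a carboxylic acid at this position would move the number beyond the scatter. The same question stands for plain hydrogen there.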